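Adding a Methoxy Group to Compound 1

The source may hold more compounds than are shown below. What is called first, only, known or untested is meant among the compounds shown, and "the series" means these compounds.

Compound 1 `O=C1C=CCC/C1=C\C=C\c1ccccc1` was tested in a functional assay on HCT-116 cells (Homo sapiens) for cytotoxicity, read by MTT assay, with a stated time of 72 h (a lower number here means a stronger inhibitor, a higher number a weaker inhibitor), where compound 1 gives 5400 nM. Among the measured compounds shown here, of the two numbers measured so far, compound 1 stands at the higher one, yet the only other compound, compound 2 `CC(=C\c1ccccc1)/C=C1\CCC=CC1=O`, is separated from it by a 1.1-fold lower number from compound 1 to compound 2 (0.05 log units; within the scatter), so the two cannot be told apart. In this assay compound 2 gives 4800 nM.

Compound 3 `COc1ccccc1/C=C/C=C1\CCC=CC1=O` has not been measured. It differs from compound 1 by methoxy in place of hydrogen on an aromatic carbon. For the measured compounds named here, the single measured step, a 1.1-fold lower number from compound 1 to compound 2 (0.05 log units; within the scatter), concerns a methyl on the chain rather than a group on the ring, so it bears on the present change only loosely; what it does show is that a small added group on this scaffold left the number essentially unchanged. With nothing else to go on, no step beyond the scatter is expected in this assay for compound 3, in either direction.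

Compound 3 is therefore estimated at 5000 nM, with a range from 2000 nM to 12000 nM, which corresponds to an expected step of a 1.1-fold lower number from compound 1 to compound 3 (0.03 log units; within the scatter).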

Compound 3, half-maximal inhibitory concentration: 2800 nM
For compound 3 the middle estimate is 1.8-fold (0.25 log units) above the measured one; measured number inside the range.
By their numbers in this assay, from the lowest: compounds 3, 2 and 1 (each within the scatter of the next).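

Putting methoxy in place of hydrogen on an aromatic carbon, ortho to a large group, is the first change on the aromatic ring among these compounds, and this assay records a 1.9-fold lower number from compound 1 to compound 3 (0.29 log units; within the scatter). This step lies within the scatter, so the two numbers cannot be told apart: this position accepts methoxy with no measurable penalty in cytotoxicity, but no gain can be claimed for it either. Nothing available gives a reason for this result or shows what the group does in the cells.

On these data alone, it remains open whether a different group on this same aromatic carbon, such as a hydroxyl, a fluorine atom, an amine or a carboxylic acid, would produce a step beyond the scatter, which would show how much this position matters for the number. As far as these compounds go, it is also open whether methoxy on another carbon of the aromatic ring would read the same, or whether methoxy combined with the chain methyl of compound 2 would move the number any further.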